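Swapping fluoro for nitro on a hepatoma cell growth inhibitor

This account rests on a few compounds, and the source may have more. Where it says the series, first, only, none or still open, it means among the compounds named here.

Measured compounds:
compound 1 `O=C(N/N=C/c1ccc(F)cc1)Nc1ccc(Oc2ccnc3[nH]ccc23)c(F)c1` with 3880 nM
compound 2 `O=C(N/N=C/c1ccc([N+](=O)[O-])cc1)Nc1ccc(Oc2ccnc3[nH]ccc23)c(F)c1` with 3030 nM
compound 3 `O=C(N/N=C/c1ccc(F)cc1)Nc1ccc(Oc2ccnc3[nH]ccc23)cc1` with 3430 nM

Of the compounds shown here, three share a common skeleton and have been tested in a functional assay on HepG2 cells (Homo sapiens) for antiproliferative activity, read by MTT assay, with a stated time of 72 h; a lower number here means a stronger inhibitor, a higher number a weaker inhibitor. Compound 1 gives 3880 nM, compound 2 gives 3030 nM, and compound 3 gives 3430 nM. All three values lie close together, and neither difference between them stands apart from the usual spread of repeated measurements.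

Compound 2 differs from compound 1 by one change, (nitro in place of fluoro on an aromatic carbon), and the step is a 1.3-fold lower number from compound 1 to compound 2 (0.11 log units; within the scatter). Compound 3 differs from compound 1 elsewhere on the core, (hydrogen in place of fluoro on an aromatic carbon), giving a 1.1-fold lower number from compound 1 to compound 3 (0.05 log units; within the scatter).

The not yet measured compound 4 `O=C(N/N=C/c1ccc([N+](=O)[O-])cc1)Nc1ccc(Oc2ccnc3[nH]ccc23)cc1` carries the same change relative to compound 3 that compound 2 carries relative to compound 1: nitro in place of fluoro on an aromatic carbon. The place of the change is described in the same words in both pairs, so this is the same change made on a core that differs only by hydrogen in place of fluoro on an aromatic carbon.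

Because a 1.3-fold lower number from compound 1 to compound 2 (0.11 log units; within the scatter) was within the scatter, the step for compound 4 is expected to be of a similar small size, a 1.3-fold lower number from compound 3 to compound 4 (0.10 log units; within the scatter). Taking compound 3 with 3430 nM as the starting point, compound 4 is expected to come in at about 2700 nM in this assay. The plausible span for compound 4 is estimated to run from 1300 nM to 5600 nM.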

Compound 4, half-maximal inhibitory concentration: 4620 nM
For compound 4 the middle estimate is 1.7-fold (0.23 log units) below the measured one, and the stated range covers the measured number.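

In this assay, changing 4-fluorophenyl to 4-nitrophenyl on the core of compound 3 gives a 1.3-fold higher number from compound 3 to compound 4 (0.13 log units; within the scatter), and this step cannot be told apart from the same change on the core of compound 1: the same change on two cores in this assay, a 1.3-fold lower number (0.11 log units; within the scatter) from compound 1 to compound 2 and a 1.3-fold higher number (0.13 log units; within the scatter) from compound 3 to compound 4, 1.7-fold (0.24 log units) apart, within the scatter of two such steps The other change, hydrogen in place of fluoro on an aromatic carbon, gives a 1.5-fold higher number from compound 2 to compound 4 (0.18 log units; within the scatter) when the 4-nitrophenyl group is present, and this step likewise cannot be told apart from its counterpart with the 4-fluorophenyl group: the same change on two cores in this assay, a 1.1-fold lower number (0.05 log units; within the scatter) from compound 1 to compound 3 and a 1.5-fold higher number (0.18 log units; within the scatter) from compound 2 to compound 4, 1.7-fold (0.24 log units) apart, within the scatter of two such steps These four compounds therefore show no measurable dependence of either change on the core, but every step is small enough to be ordinary measurement spread, so the steps' opposite printed directions are no reversal, and nothing shows that a change with a larger step would carry over in the same way.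

On these data alone, whether an amine or a carboxylic acid in place of the nitro group would move the number beyond the scatter remains open. As far as these compounds go, all four values also come from this assay, so how these same changes behave in any other kind of test remains open as well.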